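Aryl swap at the saturated ring carbon: compound 4

This account rests on a few compounds, and the source may have more. Where it says the series, first, only, none or still open, it means among the compounds named here.

Compound 1 `N#CC1=C(N)N(c2ccc(S(N)(=O)=O)cc2)C2=C(CCCC2)C1c1ccccc1`, compound 2 `N#CC1=C(N)N(c2ccc(S(N)(=O)=O)cc2)C2=C(CCCC2)C1c1ccccc1Cl` and compound 3 `Cc1ccc(C2C(C#N)=C(N)N(c3ccc(S(N)(=O)=O)cc3)C3=C2CCCC3)o1` share one core and differ only at a saturated ring carbon. In a functional assay on Ehrlich cells (Mus musculus) for cytotoxicity, read by trypan blue exclusion, with a stated time of 2 h, tested at 50 ug/mL (a lower number here means a weaker effect, a higher number a stronger effect of the compound at the concentration tested), compound 1 gives 20%, compound 2 gives 5% and compound 3 gives 10%. For the measured compounds named here, compound 3 thus stands second highest of three numbers, within the scatter of compound 2 and of compound 1; only the step of a number 15 percentage points lower from compound 1 to compound 2 (beyond the scatter) lies beyond it.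

Compound 4 `N#CC1=C(N)N(c2ccc(S(N)(=O)=O)cc2)C2=C(CCCC2)C1c1cccs1` differs from compound 3 by thiophen-2-yl in place of 5-methylfuran-2-yl on a saturated ring carbon. Two steps at the same carbon bear on this change, a number 10 percentage points lower from compound 1 to compound 3 (within the scatter) and a number 5 percentage points higher from compound 2 to compound 3 (within the scatter), both within the scatter. In this assay no step beyond the scatter is therefore expected. Compound 4 is expected to give 10%, with a range from 0% to 25%. The expected step is no change at the digits printed from compound 3 to compound 4 (within the scatter), within the scatter.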

Compound 4, a percentage reported as activity, at one concentration (the size of the read-out at that concentration, not a potency): 10%
Compound 4: the middle estimate sits on the measured number at the digits printed; low and high end bracket the measured number.
By their numbers in this assay, from the lowest: compounds 2, 3, 4 and 1 (each within the scatter of the next, the first and the last beyond it).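

In this assay, the swap of one five-membered aromatic ring for another at this saturated ring carbon gives no measurable shift (no change at the digits printed from compound 3 to compound 4 (within the scatter)). Compound 4 also stays within the scatter of the 2-chlorophenyl compound (a number 5 percentage points higher from compound 2 to compound 4 (within the scatter)) and of the phenyl compound (a number 10 percentage points lower from compound 1 to compound 4 (within the scatter)), so thiophen-2-yl adds no step beyond the scatter at this carbon. No measured evidence accounts for these results.

As far as these compounds go, whether a non-aromatic group at this carbon, such as cyclohexyl or a longer alkyl chain, would step beyond the scatter remains open. The same holds for a phenyl ring bearing a carboxylic acid or an amine.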